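Permeability notes: cyclohexyl in place of pentan-3-yl

A few compounds are considered here, and "the series" means these few. Any claim that something is new, unique, unknown or untested is made for them only; others in the source may bear on it.

Three members of the shared core have been measured in an ADME assay for permeability, using PAMPA, with a stated time of 30 min, at pH 7.4; on this read-out higher numbers stand for higher permeability and lower numbers for lower permeability. Compound 1 `CCC(CC)c1ccc2c(NCCCNCc3cc(F)ccc3OC)ccnc2c1` gives 23 10^-6 cm/s, compound 2 `CCC(CC)c1ccc2c(NCCCNCc3ccco3)ccnc2c1` gives 23 10^-6 cm/s, and compound 3 `CCC(CC)c1ccc2c(NCCCNCc3cccc(OC)c3O)ccnc2c1` gives 23 10^-6 cm/s. The measured steps of no change at the digits printed from compound 1 to compound 2 (within the scatter), no change at the digits printed from compound 1 to compound 3 (within the scatter) and no change at the digits printed from compound 2 to compound 3 (within the scatter) each exchange the group on the saturated chain carbon bound to an amine nitrogen, so compound 2 stands level with compounds 1 and 3 in this assay. Compound 4 `c1coc(CNCCCNc2ccnc3cc(C4CCCCC4)ccc23)c1` departs from compound 2 at a different site: cyclohexyl in place of pentan-3-yl on an aromatic carbon. Among the measured compounds shown here, no measured step touches the pentan-3-yl group, so the earlier steps bear only indirectly, showing a read-out that did not move in this assay across the changes tried. Compound 4 is expected to give 23 10^-6 cm/s, with a range from 12 10^-6 cm/s to 42 10^-6 cm/s. The expected step of no change at the digits printed from compound 2 to compound 4 (within the scatter) is none beyond the scatter.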

Compound 4, apparent permeability: 23 10^-6 cm/s
Beside the measured number, compound 4's estimate shows no gap at the digits printed, within the range that was stated.
By their numbers in this assay, from the lowest: compounds 1, 2, 3 and 4 (each within the scatter of the next).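

In this assay, the aromatic carbon now has a measured step of its own: cyclohexyl in place of pentan-3-yl gives no change at the digits printed from compound 2 to compound 4 (within the scatter). Among the compounds shown here, the earlier steps changed only the group on the saturated chain carbon, so this is the first sign that a six-membered non-aromatic ring of carbon only can stand at this position with the read-out level. No measured evidence bears on this result.

Going by these compounds, an amine or a carboxylic acid on this aromatic carbon remains open. So does cyclohexyl paired with 5-fluoro-2-methoxyphenyl or 2-hydroxy-3-methoxyphenyl on the chain.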